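This account rests on a few compounds, and the source may have more. Where it says the series, first, only, none or still open, it means among the compounds named here.

Measured in a functional assay on MCF7 cells (Homo sapiens) for inhibition, read by MTT assay, with a stated time of 24 h; a higher number here means a weaker inhibitor, a lower number a stronger inhibitor:
Compound 1, `CCOC(=O)C1=Cc2ccccc2OC1(OCc1cn(CC(=O)Nc2cccc(Cl)c2)nn1)C(F)(F)F`: 11600 nM.
Compound 2, `CCCCCCCCn1cc(COC2(C(F)(F)F)Oc3ccccc3C=C2C(=O)OCC)nn1`: a limit of the assay, > 150000 nM.

Compound 2 stands at the weak end of the pair; its result is only a limit, namely (the limit of > 150000 nM in this assay, at which 1 of the 2 values shown sits). Going by the values given here, the one measured step, an at least 12-fold higher number from compound 1 to compound 2 (1.11 log units; beyond the scatter), is the sole guide for what follows. Compound 3, `CCOC(=O)C1=Cc2ccccc2OC1(OCc1cn(-c2ccc(F)c([N+](=O)[O-])c2)nn1)C(F)(F)F`, is not yet measured in this assay; it differs from compound 2 by 4-fluoro-3-nitrophenyl in place of octyl on an aromatic nitrogen. This puts an aromatic group back on the aromatic nitrogen where compound 2 carries the octyl chain, the reverse in kind of the step from compound 1 to compound 2, though the entering group is not the one that left there. A move toward lower numbers is therefore expected in this assay, of uncertain size, and compound 3 may still give only a limit. The estimate for compound 3 is 30000 nM, within 8000 nM to 150000 nM. This expected value for compound 3 means a step of an at least 5.0-fold lower number from compound 2 to compound 3 (0.69 log units; beyond the scatter).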

Compound 3, half-maximal inhibitory concentration: 16200 nM
Beside the measured number, compound 3's estimate is 1.9-fold (0.27 log units) above it; the range from low to high includes it.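

On the aromatic nitrogen, a directly attached aromatic ring is compatible with activity in this assay, whereas the octyl chain is not: an at least 9.2-fold lower number from compound 2 to compound 3 (0.96 log units; beyond the scatter). Going by these compounds, the size of this step stays open, since the result for compound 2 is only a limit: the limit of > 150000 nM in this assay, at which 1 of the 3 values shown sits. The 4-fluoro-3-nitrophenyl and ((3-chlorophenyl)carbamoyl)methyl groups read alike at this position, a 1.4-fold higher number from compound 1 to compound 3 (0.15 log units; within the scatter), so among the compounds shown a carbamoyl link is not needed for this level of inhibition.

Plain phenyl on the same nitrogen would show whether the fluoro and nitro groups contribute anything beyond the ring itself. A shorter chain such as butyl, or a chain ending in an amine or a carboxylic acid, would show whether the weak result of compound 2 belongs to alkyl groups generally or to octyl alone.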